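Ether versus lactone core with ethoxy and butoxy side chains

This account rests on a few compounds, and the source may have more. Where it says the series, first, only, none or still open, it means among the compounds named here.

Compound 1 `CCOc1ccccc1C[C@H]1COC(=O)[C@@H]1Cc1ccc(Cl)c(Cl)c1` and compound 2 `CCCCOc1ccccc1C[C@H]1COC(=O)[C@@H]1Cc1ccc(Cl)c(Cl)c1` share a lactone core and differ by ethyl in place of hydrogen on a saturated chain carbon, two bonds along the chain from an oxygen on an aromatic ring. In a functional assay on HL-60 cells (Homo sapiens) for cytotoxicity, read by WST assay, with a stated time of 48 h (a higher number here means that more compound is needed for the effect, a lower number that less compound is needed), compound 1 gives 15000 nM, and compound 2 gives 10000 nM, so that a 1.5-fold lower number from compound 1 to compound 2 (0.18 log units; within the scatter). Compound 3 `CCOc1ccccc1C[C@H]1COC[C@@H]1Cc1ccc(Cl)c(Cl)c1` carries the ethoxy chain on a core without the carbonyl; the difference between the core of compound 3 and the core of compound 1 is not broken down here. In this assay compound 3 gives 29000 nM, and the gap to compound 1 is within the scatter, while the gap to compound 2 is beyond it.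

Compound 4 `CCCCOc1ccccc1C[C@H]1COC[C@@H]1Cc1ccc(Cl)c(Cl)c1` is not yet measured in this assay. Among the measured compounds shown here, compound 4 differs from compound 3 by ethyl in place of hydrogen on a saturated chain carbon, two bonds along the chain from an oxygen on an aromatic ring, which is the same change as the one from compound 1 to compound 2, made at the same place. For the measured compounds named here, the step from compound 3 to compound 4 in this assay is expected to be a 1.5-fold lower number from compound 3 to compound 4 (0.18 log units; within the scatter), because the only measured instance of this change is a 1.5-fold lower number from compound 1 to compound 2 (0.18 log units; within the scatter) on the other core. Compound 4 is therefore estimated at 19000 nM in this assay, with the expected range 9000 nM to 40000 nM.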

Compound 4, half-maximal effective concentration: 20000 nM
Beside the measured number, compound 4's estimate is 1.1-fold (0.02 log units) below it, within the range that was stated.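

In this assay, going from the ethoxy to the butoxy chain on the core without the carbonyl gives a 1.5-fold lower number from compound 3 to compound 4 (0.16 log units; within the scatter). On the two cores shown, this change comes out at matching size: the same change on two cores in this assay, a 1.5-fold lower number (0.18 log units; within the scatter) from compound 1 to compound 2 and a 1.5-fold lower number (0.16 log units; within the scatter) from compound 3 to compound 4, 1.0-fold (0.01 log units) apart, within the scatter of two such steps

This agreement does not show that the butoxy chain has a real effect on either core, since each step lies within the scatter, and a match between two such steps says little about how a larger step would carry over. It also rests on a single pair of cores, so nothing follows for any further core in the series.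

Open, from the compounds shown here alone, is whether a chain longer than butoxy, or a chain ending in an amine or a carboxylic acid, would give a step beyond the scatter on either core. Also open, going by these compounds, is whether the two cores would still match with a methoxy group in place of the chlorines.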